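Naphthalene-fused isoxazolidine series: cytotoxicity on Vero cells

The source may hold more compounds than are shown below. What is called first, only, known or untested is meant among the compounds shown, and "the series" means these compounds.

Compound 1 `Clc1ccc([C@@H]2C[C@@H]3Cc4ccc5ccccc5c4N2O3)cc1` gives 287000 nM in an ADME assay on Vero cells (Chlorocebus sabaeus) for cytotoxicity, read by MTT assay, with a stated time of 72 h; on this read-out lower numbers stand for higher toxicity in this test and higher numbers for lower toxicity in this test.
Compound 2 `Clc1cccc([C@@H]2C[C@@H]3Cc4ccc5ccccc5c4N2O3)c1` reaches only a limit in this assay, > 300000 nM.
Compound 3 `Brc1cccc([C@@H]2C[C@@H]3Cc4ccc5ccccc5c4N2O3)c1` likewise gives only a limit in this assay, > 250000 nM.

Compound 3 thus stands at the limit of > 250000 nM in this assay, at which 1 of the 3 values shown sits, in this assay, so its position among the three can be told only as a limit. Going by the values given here, the one readable step, an at least 1.0-fold higher number from compound 1 to compound 2 (0.01 log units; that floor lies within the scatter), lies within the scatter. The steps a step that the limit leaves unreadable from compound 1 to compound 3 and a step that the two limits leave unreadable from compound 2 to compound 3 cannot be sized, the second because compound 2 sits at the limit of > 300000 nM in this assay, at which 1 of the 3 values shown sits, and compound 3 at the limit of > 250000 nM in this assay, at which 1 of the 3 values shown sits.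

Compound 4 `COc1cccc([C@@H]2C[C@@H]3Cc4ccc5ccccc5c4N2O3)c1` carries the change (methoxy in place of bromo on an aromatic carbon). None of the measured steps concerns a methoxy group, and the halogen exchanges shown gave no readable movement in this assay. The expectation is therefore a step that the limit leaves unreadable from compound 3 to compound 4 from compound 3 to compound 4, none beyond the scatter, with a high chance that only a limit is reported again. Compound 4 is estimated at 280000 nM in this assay, with a range from 140000 nM to 600000 nM.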

Compound 4, half-maximal cytotoxic concentration: > 300000 nM
Compound 4 ended at the assay's limit; the forecaster's own chance of this, stated with the estimate: 65%; middle value at least 1.0-fold (0.02 log units) from the limit.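

Compound 4 also gives only a limit in this assay: the limit of > 300000 nM in this assay, at which 2 of the 4 values shown sit. On the aromatic carbon meta to a large group, the series now includes methoxy, with its hydrogen-bond acceptor, as well as chloro and bromo, and none of these three compounds gives a value that is more than a limit. Going by these compounds alone, the only readable step involving compound 4, an at least 1.0-fold higher number from compound 1 to compound 4 (0.01 log units; that floor lies within the scatter), does not separate the 3-methoxyphenyl and 4-chlorophenyl compounds, and the steps from compound 2 and compound 3 to compound 4 cannot be read.

The limits leave open whether compound 2, compound 3 and compound 4 differ at all in this read-out. On these data alone, it also remains open whether an amine or a carboxylic acid in the same place would give a measured number rather than another limit.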